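Hydroxymethyl amides: the step from compound 3 to compound 4

A few compounds are considered here, and "the series" means these few. Any claim that something is new, unique, unknown or untested is made for them only; others in the source may bear on it.

Measured in a functional assay on MCF7 cells (Homo sapiens) for antiproliferative activity, read by MTT assay, with a stated time of 24 h; on this read-out higher numbers stand for weaker inhibition and lower numbers for stronger inhibition:
- compound 1 `CCn1c(C(=O)NCCC(=O)OC)ccc1C(CC)(CC)c1ccc(OCS(=O)(=O)c2ccccc2)c(C)c1`: > 50000 nM (a limit)
- compound 2 `CCn1c(C(=O)NCCNC(=O)OC(C)(C)C)ccc1C(CC)(CC)c1ccc(OCS(=O)(=O)c2ccccc2)c(C)c1`: > 50000 nM (a limit)
- compound 3 `CCn1c(C(=O)N[C@H](C)CO)ccc1C(CC)(CC)c1ccc(OCS(=O)(=O)c2ccccc2)c(C)c1`: 10600 nM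

Two of the three entries are therefore limits and not numbers: the limit of > 50000 nM in this assay, at which 2 of the 3 values shown sit. Among these three, only compound 3 has a measured number, 10600 nM.

Compound 4 `CCn1c(C(=O)NC2(CO)CC2)ccc1C(CC)(CC)c1ccc(OCS(=O)(=O)c2ccccc2)c(C)c1` keeps the shared core and differs from compound 3 only on the amide-type nitrogen: 1-(hydroxymethyl)cyclopropyl in place of 1-(hydroxymethyl)ethyl on an amide-type nitrogen.

Within the data shown here, two measured steps bear on this change: an at least 4.7-fold lower number from compound 1 to compound 3 (0.67 log units; beyond the scatter) and an at least 4.7-fold lower number from compound 2 to compound 3 (0.67 log units; beyond the scatter). Both end at the 1-(hydroxymethyl)ethyl group of compound 3, and both are sized against a limit. The remaining step, a step that the two limits leave unreadable from compound 1 to compound 2, cannot be read. Among the measured compounds shown here, no measured step tests a 1-(hydroxymethyl)cyclopropyl group, so the data give no direction for the change. Compound 4 retains the hydroxymethyl of compound 3, which stands at 10600 nM, so a number in the same region is expected in this assay, with no step beyond the scatter. The expected change is a 1.0-fold higher number from compound 3 to compound 4 (0.02 log units; within the scatter). For compound 4 the estimated value is 11000 nM, with an expected range from 4500 nM to 30000 nM.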

Compound 4, half-maximal inhibitory concentration: 28800 nM
For compound 4 the middle estimate is 2.6-fold (0.42 log units) below the measured one, within the range that was stated.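

In this assay, this change shows that the amide-type nitrogen remains sensitive to its substituent even when the hydroxymethyl is retained: 1-(hydroxymethyl)cyclopropyl in place of 1-(hydroxymethyl)ethyl gives a 2.7-fold higher number from compound 3 to compound 4 (0.43 log units; beyond the scatter). The margin seen for compound 3 over the two open chains ending in methoxycarbonyl and (tert-butoxycarbonyl)amino is not established for the cyclopropyl group, with an at least 1.7-fold lower number from compound 2 to compound 4 (0.23 log units; that floor lies within the scatter) and an at least 1.7-fold lower number from compound 1 to compound 4 (0.23 log units; that floor lies within the scatter). Both of these steps are sized against a limit and not against a number: the limit of > 50000 nM in this assay, at which 2 of the 4 values shown sit.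

Among these compounds, the single step from compound 3 to compound 4 adds a three-membered ring and removes the defined stereocentre, so the contribution of each remains unseparated, and the opposite stereoisomer of the 1-(hydroxymethyl)ethyl group would bear on this question. On these data alone, how a 1-(hydroxymethyl)cyclobutyl group, a longer hydroxyalkyl chain, a free primary amine or a carboxylic acid on the amide-type nitrogen would read in this assay also stays open.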